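Benzoyl for fluoro on the anilide of compound 1

The source may hold more compounds than are shown below. What is called first, only, known or untested is meant among the compounds shown, and "the series" means these compounds.

Going by the values given here, compound 1 `COc1ccc(C(=O)Nc2ccccc2F)cc1OC1CCCC1` gives 10700 nM in an assay on isolated protein for inhibition of phosphodiesterase 4A (Sus scrofa) (a lower number here means a stronger inhibitor, a higher number a weaker inhibitor), the highest of the two numbers known; its nearest neighbour, compound 2 `COc1ccc(C(=O)Nc2c(F)cccc2F)cc1OC1CCCC1`, gives 70 nM in this assay. Among the compounds with values here, the single measured step, a 150-fold lower number from compound 1 to compound 2 (2.18 log units; beyond the scatter), comes from a fluoro in place of hydrogen on an aromatic carbon. Compound 3 `COc1ccc(C(=O)Nc2ccccc2C(=O)c2ccccc2)cc1OC1CCCC1` instead carries benzoyl in place of fluoro on an aromatic carbon, at a place ortho to a large group. Within the data shown here, no measured step bears on swapping fluoro for benzoyl, so the expectation leans only on compound 1 and its 10700 nM. For compound 3 a modest gain is expected, a 3.6-fold lower number from compound 1 to compound 3 (0.55 log units; beyond the scatter), estimated at 3000 nM within 300 nM to 30000 nM.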

Compound 3, half-maximal inhibitory concentration: 1700 nM
For compound 3 the middle estimate is 1.8-fold (0.25 log units) above the measured one, and the stated range covers the measured number.
By their numbers in this assay, from the lowest: compound 2; then compound 3; then compound 1.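

In this assay, benzoyl in place of fluoro on an aromatic carbon, ortho to a large group, gives a 6.3-fold lower number from compound 1 to compound 3 (0.80 log units; beyond the scatter) and so improves on compound 1. The fluoro step did not show that this place tolerates a much larger substituent: here 8 heavy atoms, including a six-membered aromatic ring, replace a single fluorine with no loss. Nothing measured accounts for this step.

As far as these compounds go, whether the gain comes from the carbonyl or from the added phenyl ring remains open. An acetyl or an amine at this place could help separate the two.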